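Adding an Ethyl Group to a Small Aryl Acid

A few compounds are considered here, and "the series" means these few. Any claim that something is new, unique, unknown or untested is made for them only; others in the source may bear on it.

Measured so far:
compound 1 `O=C(O)/C=C/C(=O)c1ccccc1` — 30200 nM
compound 2 `CCCCCCCCCCCCc1ccc(C(=O)/C=C/C(=O)O)cc1` — 4010 nM
compound 3 `CC(C)c1ccc(C(C)C)c(C(=O)/C=C/C(=O)O)c1` — 3280 nM

All three were tested in a functional assay on K562 cells (Homo sapiens) for inhibition, read by MTT assay, with a stated time of 72 h; a lower number here means a stronger inhibitor, a higher number a weaker inhibitor. Compound 1 gives the highest number of the three; compound 2 and compound 3, each carrying larger alkyl groups on the ring, both give lower numbers, and both gaps lie beyond the scatter.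

Compound 4 `CCc1ccc(C(=O)/C=C/C(=O)O)cc1` has not yet been measured. It differs from compound 1 by one change: ethyl in place of hydrogen on an aromatic carbon. Going by the values given here, no measured pair shows exactly this change, so its effect can only be estimated. Since compound 2 and compound 3 both sit well below compound 1, a modest lowering is expected from compound 1 to compound 4, a 2.5-fold lower number from compound 1 to compound 4 (0.40 log units; beyond the scatter), probably beyond the scatter. Compound 4 is expected to give about 12000 nM, within a range from 5000 nM to 30000 nM.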

Compound 4, half-maximal inhibitory concentration: 5530 nM
Beside the measured number, compound 4's estimate is 2.2-fold (0.34 log units) above it; measured number inside the range.
By their numbers in this assay, from the lowest: compounds 3, 2 and 4 (each within the scatter of the next); then compound 1.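

In this assay, going by these compounds alone, ethyl in place of hydrogen on an aromatic carbon gives a 5.5-fold lower number from compound 1 to compound 4 (0.74 log units; beyond the scatter) and so provides the first direct reading of a single change at this position. A group of only 2 carbon atoms is already enough to move the number beyond the scatter, and compound 4 stands within the scatter of compound 2, which has a much longer chain at that place. No measured evidence here explains this step. Going by these compounds, it remains open whether a methyl group, an amine or a carboxylic acid at this position would lower the number in the same way.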